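The source may report more compounds than this note shows. Statements on the series, on what has been measured and on what is new or still open speak of the compounds shown alone.

Compound 1 `C[C@H]1N=C2C[C@H]3C[C@H](C3(C)C)[C@@]2(C)OC1=O` gives > 1800000 nM in an ADME assay on McCoy cells (Mus musculus) for antiproliferative activity, read by sulforhodamine B assay, with a stated time of 48 h (on this read-out higher numbers stand for weaker inhibition and lower numbers for stronger inhibition), which is a limit of the assay rather than a number.
Compound 2 `CC1(C)[C@H]2CC3=N[C@H](CCC(=O)O)C(=O)O[C@]3(C)[C@@H]1C2` gives > 1200000 nM in this assay, likewise a limit rather than a number.

Compound 2 therefore stands only at a limit, and compound 1 stands at a limit too, so neither can be placed against the other. The step that the two limits leave unreadable from compound 1 to compound 2 is of unreadable size because the limit of > 1200000 nM in this assay, at which 1 of the 2 values shown sits, and the limit of > 1800000 nM in this assay, at which 1 of the 2 values shown sits, cap both of its ends.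

Compound 3 `CC(C)(C)OC(=O)CC[C@H]1N=C2C[C@H]3C[C@H](C3(C)C)[C@@]2(C)OC1=O` differs from compound 2 by tert-butyl in place of hydrogen on an oxygen next to a carbonyl group. For the measured compounds named here, the only measured step that bears on it is the one from compound 1 to compound 2, and that step could not be read, so there is no measured ground for expecting a step beyond the scatter in this assay in either direction. The expected step is a step that the limit leaves unreadable from compound 2 to compound 3. Compound 3 is estimated at 1500000 nM, with a range from 300000 nM to 6000000 nM, and most likely the assay will again report only a limit.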

Compound 3, half-maximal inhibitory concentration: > 1200000 nM
Compound 3 gave a limit, no number; the forecaster's own chance of this, stated with the estimate: 85%; the middle value does not contradict the limit.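

In this assay compound 3 gives > 1200000 nM, again a limit of the assay and not a number. For the compounds shown here, no step among compound 1, compound 2 and compound 3 can be read. On these data alone, what stays open is whether these compounds differ in activity at all, and what actual half-maximal inhibitory concentration any of them has.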